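This account rests on a few compounds, and the source may have more. Where it says the series, first, only, none or still open, it means among the compounds named here.

Of the compounds shown here, three sharing a common core have been tested in a functional assay on SF-268 cells (Homo sapiens) for cytotoxicity, read by sulforhodamine B assay, with a stated time of 48 h, tested at 1 uM; on this read-out higher numbers stand for a weaker effect at the one concentration tested and lower numbers for a stronger effect. Compound 1, with the structure `COc1cc(-c2cc(/C=C/C(=O)c3ccc(Cl)c(Cl)c3)[nH]n2)cc(OC)c1OC`, gives 92% in this assay, the highest of the three numbers and so the weakest effect of the three. Compound 2, with the structure `COc1ccc(-c2cc(/C=C/C(=O)c3cc(OC)c(OC)c(OC)c3)[nH]n2)cc1OC`, gives 81% in this assay, and compound 3, with the structure `COc1ccc(-c2cc(/C=C/C(=O)c3ccc(N)cc3)[nH]n2)cc1`, gives 78%. Both of these numbers lie more than the usual scatter below that of compound 1, so the weaker effect of compound 1 is a real difference rather than noise.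

Compound 4, with the structure `COc1cc(-c2cc(/C=C/C(=O)c3ccc(F)c(F)c3)[nH]n2)cc(OC)c1OC`, has not yet been measured. It differs from compound 1 in one place: 3,4-difluorophenyl in place of 3,4-dichlorophenyl on a carbonyl carbon. Among the compounds with values here, no pair of measured compounds differs in just this way, so nothing in the data shows what this exchange does to the read-out. The exchange swaps one pair of halogens for another on the same ring and leaves the rest of the molecule untouched. Within the data shown here, with no step to lean on, the step of a number 1 percentage points higher from compound 1 to compound 4 (within the scatter) is expected to be small, within the usual scatter or at most slightly upward. Compound 4 is therefore estimated to give 93% in this assay, with a likely range from 80% to 102%.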

Compound 4, a percentage reported as activity, at one concentration (the size of the read-out at that concentration, not a potency): 83%
Estimate against measurement, compound 4: 10 percentage points above, and the stated range covers the measured number.
By their numbers in this assay, from the lowest: compounds 3, 2, 4 and 1 (each within the scatter of the next, the first and the last beyond it).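

Within the data shown here, compound 1 and compound 4 form the first pair here that differs in one place, so this position can now be read directly. In this assay, exchanging 3,4-dichlorophenyl for 3,4-difluorophenyl on a carbonyl carbon gives a number 9 percentage points lower from compound 1 to compound 4 (within the scatter), so this one swap of halogens, with the rest of the molecule unchanged, produces no difference that can be told apart from the spread of repeated measurements. Nothing available explains this outcome or links it to any property of the two halogens.

Among these compounds, the step covers only one exchange of halogen for halogen at a single concentration, so it says nothing about a group of a different kind, such as a nitrile or a carboxylic acid, in place of the two halogens on this ring. The three methoxy groups on the other aromatic ring also stay the same in compound 1 and compound 4, which leaves open what replacing them with a single hydroxyl group would do to the read-out.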